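The compounds below may be only part of what the source reports. "The series", "measured", "known", "first", "only" and "open" are said of these compounds alone.

Compound 1: `COc1ccc(C(=O)N(O)C(C)c2ccc3oc(-c4ccccc4)cc3c2)cc1OC` with 200 nM
Compound 2: `CC(c1ccc2oc(-c3ccccc3)cc2c1)N(O)C(=O)c1ccco1` with 40 nM
Compound 3: `CCCCCCCCCCc1cc2cc(C(C)N(O)C(=O)CCCC(=O)OC)ccc2o1` with 150 nM

In an assay on RBL cells for inhibition of Polyunsaturated fatty acid 5-lipoxygenase (Rattus norvegicus) (a lower number here means a stronger inhibitor, a higher number a weaker inhibitor), compound 1 gives the highest of the three numbers. Compound 3 gives 150 nM, which sits within the scatter of the value of compound 1, so no order between the two can be read. Compound 2 is the furthest from compound 1: the step of a 5.0-fold lower number from compound 1 to compound 2 (0.70 log units; beyond the scatter) is a modest but real lowering. That step is a change at the carbonyl carbon.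

Compound 4 has the structure `CC(c1ccc2oc(-c3ccccc3)cc2c1)N(O)C(N)=O`. Relative to compound 1 it carries amino in place of 3,4-dimethoxyphenyl on a carbonyl carbon. For the measured compounds named here, the only measured step that bears on this change is a 5.0-fold lower number from compound 1 to compound 2 (0.70 log units; beyond the scatter), since it too swaps the same 3,4-dimethoxyphenyl at the same carbonyl carbon for a much smaller group. That step was modest in size and downward. Going by the values given here, the amino group is smaller still and brings no ring, so how far the pattern carries is uncertain; no measured pair tests a change of this kind directly.

On this basis compound 4 is expected to show a step of about a 2.2-fold lower number from compound 1 to compound 4 (0.35 log units; beyond the scatter). The estimate for compound 4 is 90 nM, with a range from 30 nM to 350 nM.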

Compound 4, half-maximal inhibitory concentration: 410 nM
Estimate against measurement, compound 4: 4.6-fold (0.66 log units) below, and the stated range ends below it.
By their numbers in this assay, from the lowest: compound 2; then compounds 3 and 1 (each within the scatter of the next); then compound 4.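

In this assay, taking away the 3,4-dimethoxyphenyl on the carbonyl carbon does not move the number in one fixed direction: furan-2-yl had lowered it, whereas amino gives a 2.1-fold higher number from compound 1 to compound 4 (0.31 log units; beyond the scatter). The direction of the step at this position therefore follows the group that enters, and losing the 3,4-dimethoxyphenyl ring is not enough on its own to lower the number. The sharper contrast is between the two small groups, with amino in place of furan-2-yl giving a 10-fold higher number from compound 2 to compound 4 (1.01 log units; beyond the scatter), the largest step among these compounds, although nothing measured here accounts for this difference.

The compounds shown leave open whether the lower number of compound 2 belongs to furan-2-yl in particular or to any small ring on this carbonyl carbon, a question that phenyl or thiophen-2-yl at the same place would address. They also leave open whether the higher number of compound 4 goes with the amino group itself or with the absence of a ring, which methyl or methylamino at this carbon could help to separate.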